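Fluoro for chloro on the benzylamine aryl ring

A few compounds are considered here, and "the series" means these few. Any claim that something is new, unique, unknown or untested is made for them only; others in the source may bear on it.

Compound 1 `O=[N+]([O-])c1cn2c(n1)OC[C@@H](NCc1ccc(OC(F)(F)F)c(Cl)c1)C2` carries a secondary benzylamine on the shared core. In a physicochemical assay for solubility, at pH 6.8 (a lower number here means a less soluble compound, a higher number a more soluble compound), compound 1 gives 77 ug/mL. Compound 2 `CCCN(Cc1ccc(OC(F)(F)F)cc1)[C@@H]1COc2nc([N+](=O)[O-])cn2C1` bears a propyl group on the same nitrogen and lacks the ring chloro. In this assay compound 2 returns < 2 ug/mL, which is a limit of the assay rather than a number. For the measured compounds named here, compound 1 therefore holds the only numerical reading in the set; the other entry rests at the limit of < 2 ug/mL in this assay, at which 1 of the 2 values shown sits. Going by the values given here, no two measured compounds differ in a single place, so no measured step is available.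

Compound 3 `O=[N+]([O-])c1cn2c(n1)OC[C@@H](NCc1ccc(OC(F)(F)F)c(F)c1)C2` differs from compound 1 by fluoro in place of chloro on an aromatic carbon. Among the compounds with values here, with no comparable step in hand, the change is expected to move solubility little, if at all, beyond the usual scatter, perhaps slightly upward. Compound 3 is estimated at 110 ug/mL, within 50 ug/mL to 250 ug/mL, an expected step of a 1.4-fold higher number from compound 1 to compound 3 (0.15 log units; within the scatter).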

Compound 3, solubility: 43 ug/mL
Compound 3: middle estimate off by 2.6-fold (0.41 log units), on the high side, outside the stated range (below it).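

Within this assay the first single-place comparison in the series, fluoro in place of chloro on an aromatic carbon ortho to a trifluoromethoxy group, reads a 1.8-fold lower number from compound 1 to compound 3 (0.25 log units; within the scatter) and gives no separation between the two halogens at this position. On this one pair, the exchange of one halogen for the other cannot be ranked, and no general rule for the position follows from it. Nothing measured in the series accounts for the step.

From the compounds shown here alone, whether a nitrile or a methoxy group at this position would move the reading beyond the scatter remains open, as does the separate contribution of a propyl group on the nitrogen. Compound 2 reads < 2 ug/mL, a limit of the assay and not a number, and it offers no single-place comparison.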